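The source may report more compounds than this note shows. Statements on the series, on what has been measured and on what is new or still open speak of the compounds shown alone.

Compound 1 `CCC(CC)/N=C(\NC#N)Nc1cccnc1` and compound 2 `N#CN/C(=N\C1CCCC1)Nc1cccnc1` share one core and differ only at a double-bonded nitrogen. In a functional assay on the whole organism (blood, strain Wistar-Okamoto) with Rattus norvegicus as the target, with a stated time of 5 days (on this read-out lower numbers stand for an effect already at smaller amounts and higher numbers for an effect only at larger amounts of compound), compound 1 gives 20 mg/kg, and in this assay compound 2 gives 20 mg/kg; the step of no change at the digits printed from compound 1 to compound 2 (within the scatter) lies within the scatter, so compound 2 stands level with compound 1. Compound 3 `N#CN/C(=N\CC1CCCO1)Nc1cccnc1` carries (oxolan-2-yl)methyl in place of cyclopentyl on a double-bonded nitrogen. Going by the values given here, only the step from compound 1 to compound 2 bears on this change, and it showed nothing beyond the scatter, so in this assay no step beyond the scatter is expected, with the expected step being no change at the digits printed from compound 2 to compound 3 (within the scatter). Compound 3 is therefore estimated at 20 mg/kg, with a range from 10 mg/kg to 40 mg/kg.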

Compound 3, minimum effective dose: 50 mg/kg
For compound 3 the middle estimate is 2.5-fold (0.40 log units) below the measured one; the whole stated range lies below it.
By their numbers in this assay, from the lowest: compounds 1 and 2 (each within the scatter of the next); then compound 3.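

Pentan-3-yl and cyclopentyl could not be told apart, but (oxolan-2-yl)methyl shows that the read-out at this double-bonded nitrogen does respond to the group placed there: in this assay there is a 2.5-fold higher number from compound 2 to compound 3 (0.40 log units; beyond the scatter) and a 2.5-fold higher number from compound 1 to compound 3 (0.40 log units; beyond the scatter). The entering group carries a ring oxygen and a hydrogen-bond acceptor that cyclopentyl lacks. No measurement at hand accounts for the shift. The compounds shown leave open whether the ring oxygen or the linking carbon goes with this step. From the compounds shown here alone, a plain cyclopentylmethyl group would separate the two, and how an amine or a longer chain behaves at this nitrogen also remains open.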